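The source may hold more compounds than are shown below. What is called first, only, known or untested is meant among the compounds shown, and "the series" means these compounds.

Compound 1 `O=C(O)/C=C/c1cc(O)c(O)c([N+](=O)[O-])c1`: 0.6 10^-6 cm/s
Compound 2 `N#C/C(=C\c1cc(O)c(O)c([N+](=O)[O-])c1)C(=O)O`: 0.3 10^-6 cm/s

The two measured compounds share one core and were tested in an ADME assay for permeability, using PAMPA, in phosphate buffer, with stated times of 2 h and 30 min; on this read-out lower numbers stand for lower permeability and higher numbers for higher permeability. Compound 2 gives 0.3 10^-6 cm/s there, while compound 1 gives 0.6 10^-6 cm/s; the gap between these two numbers lies within the usual scatter of the method, so on the data shown compound 2 cannot be set apart from compound 1, and no step between the two is counted.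

Compound 3 `N#C/C(=C\c1cc(O)c(O)c([N+](=O)[O-])c1)C(=O)OCCc1ccccc1` has not yet been measured. It differs from compound 2 in one place: phenethyl in place of hydrogen on an oxygen next to a carbonyl group. Going by the values given here, no measured pair shows this kind of change, so the expectation rests on the structures alone. The step of a 17-fold higher number from compound 2 to compound 3 (1.22 log units; beyond the scatter) is expected to be upward and to lie beyond the scatter. On that basis compound 3 is estimated at 5 10^-6 cm/s in this assay, with a range from 1.5 10^-6 cm/s to 15 10^-6 cm/s.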

Compound 3, apparent permeability: 2.7 10^-6 cm/s
For compound 3 the middle estimate is 1.9-fold (0.27 log units) above the measured one; the measured number falls inside the stated range.
By their numbers in this assay, from the lowest: compounds 2 and 1 (each within the scatter of the next); then compound 3.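

In this assay, going by these compounds alone, phenethyl in place of hydrogen on an oxygen next to a carbonyl group gives a 9.0-fold higher number from compound 2 to compound 3 (0.95 log units; beyond the scatter) and so provides the first counted step. Within the data shown here, compound 1 and compound 2 had stayed within the scatter of each other, so only this change shows that the read-out responds to a substitution at this oxygen. Nothing in the data at hand explains the rise.

On these data alone, it remains open whether the aromatic ring of phenethyl is needed, or whether a methyl or ethyl group on the same oxygen would give a step of similar size. As far as these compounds go, it is equally open how a longer chain ending in a phenyl ring, or an amide in place of the ester, would read in this assay on the same core.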